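Three pyrazole chalcones and a fourth awaiting its cytotoxicity number

This account rests on a few compounds, and the source may have more. Where it says the series, first, only, none or still open, it means among the compounds named here.

The study compares three measured compounds with a fourth that is not yet measured. Compound 1 `COc1ccc(-c2cc(/C=C/C(=O)c3ccc(N)cc3)[nH]n2)cc1`, compound 2 `COc1ccc(C(=O)/C=C/c2cc(-c3cc(OC)c(OC)c(OC)c3)n[nH]2)cc1OC` and compound 3 `COc1ccc(-c2cc(/C=C/C(=O)c3ccc(N)cc3)[nH]n2)cc1OC` were tested in a functional assay on BT-549 cells (Homo sapiens) for cytotoxicity, read by sulforhodamine B assay, with a stated time of 48 h, tested at 100 uM; on this read-out higher numbers stand for a weaker effect at the one concentration tested and lower numbers for a stronger effect. In this assay compound 1 gives -61%, compound 2 gives -75% and compound 3 gives -98%. The change from compound 1 to compound 3 is methoxy in place of hydrogen on an aromatic carbon, and it moves the read-out by a number 37 percentage points lower from compound 1 to compound 3 (beyond the scatter). The difference between the cores of compound 1 and compound 2 is not broken down here. Compound 4 `COc1cc(C(=O)/C=C/c2cc(-c3cc(OC)c(OC)c(OC)c3)n[nH]2)cc(OC)c1OC` arises from compound 2 by the same kind of change, (methoxy in place of hydrogen on an aromatic carbon), with the entering group also meta to a methoxy group. Compound 4 is expected to show a step of a number 20 percentage points lower from compound 2 to compound 4 (beyond the scatter), resting on the step from compound 1 to compound 3 a number 37 percentage points lower from compound 1 to compound 3 (beyond the scatter). Compound 4 is thus estimated at -95%, between -100% and -80%.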

Compound 4, a percentage reported as activity, at one concentration (the size of the read-out at that concentration, not a potency): -94%
Compound 4: middle estimate off by 1 percentage points, on the low side; the range from low to high includes it.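

In this assay, methoxy in place of hydrogen on an aromatic carbon again strengthens the effect, with the read-out moving by a number 19 percentage points lower from compound 2 to compound 4 (beyond the scatter). The direction of the step thus carries over between the two cores, but its size does not: the same change on two cores in this assay, a number 37 percentage points lower (beyond the scatter) from compound 1 to compound 3 and a number 19 percentage points lower (beyond the scatter) from compound 2 to compound 4, 18 percentage points apart, beyond the scatter of two such steps These two pairs do not show what sets the size of the step, nor whether the direction would hold on a further core.

The compounds shown leave open whether a different group in the same place, such as an ethoxy, a hydroxy or a fluorine, would move the read-out the same way. They also leave open how the compounds would compare at other concentrations.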